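This account rests on a few compounds, and the source may have more. Where it says the series, first, only, none or still open, it means among the compounds named here.

Measured in a functional assay on UACC-62 cells (Homo sapiens) for inhibition, read by sulforhodamine B assay, with a stated time of 48 h; on this read-out lower numbers stand for stronger inhibition of growth and higher numbers for weaker inhibition of growth:

Compound 2, `CC1=CC[C@H](C(C)(C)NC(=S)N/N=C/c2ccco2)CC1`, gives 14100 nM.
Compound 1, `CC1=CC[C@H](C(C)(C)NC(=S)N/N=C/c2ccccc2Cl)CC1`, gives 98000 nM.

Going by the values given here, on these two numbers compound 2 stands lowest, and the only measured step reaching it is a 7.0-fold lower number from compound 1 to compound 2 (0.84 log units; beyond the scatter). That step swaps one aromatic group for another on the carbon carrying the double bond to nitrogen, while the shared core is untouched.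

Compound 3, `CC1=CC[C@H](C(C)(C)NC(=S)N/N=C/c2cccs2)CC1`, has not yet been measured. It differs from compound 2 by thiophen-2-yl in place of furan-2-yl on a carbon with a double bond to nitrogen. This again changes only the aromatic group at the same place, so the measured step from compound 1 to compound 2 is the one that bears on it. That step was modest in size, yet it compared a six-membered ring against a five-membered one; here one five-membered ring with a single hetero atom is exchanged for another of the same size and shape. Among the compounds with values here, no measured pair reports this particular exchange.

Because compound 2 gives 14100 nM, and the exchange is small, the expected step is a 1.2-fold lower number from compound 2 to compound 3 (0.07 log units; within the scatter), within the usual scatter. Compound 3 is therefore estimated at 12000 nM, between 5000 nM and 30000 nM.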

Compound 3, concentration for total growth inhibition: 19000 nM
The estimate for compound 3 lay 1.6-fold (0.20 log units) below the measured number, within the range that was stated.
By their numbers in this assay, from the lowest: compounds 2 and 3 (each within the scatter of the next); then compound 1.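

In this assay, thiophen-2-yl in place of furan-2-yl gives a 1.3-fold higher number from compound 2 to compound 3 (0.13 log units; within the scatter) and so lies within the usual scatter: on a carbon with a double bond to nitrogen, this assay does not tell these two five-membered aromatic rings apart, even though one holds oxygen and the other sulfur. The gap first seen with furan-2-yl now appears with a second group as well, with a 5.2-fold lower number from compound 1 to compound 3 (0.71 log units; beyond the scatter) beyond the scatter, so it does not rest on furan-2-yl alone and sets both five-membered rings apart from the 2-chlorophenyl of compound 1. No independent measurement on these compounds bears on what lies behind these numbers.

As far as these compounds go, what plain phenyl would give at this place remains open, and with it the question of whether the gap to compound 1 goes with the size of the ring or with the chlorine it carries. Also open, from the compounds shown here alone, is how a five-membered aromatic ring holding nitrogen, such as pyrrol-2-yl or imidazol-2-yl, would read at the same place.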